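Notes on a 4-cyanophenyl replacement in the series

This account rests on a few compounds, and the source may have more. Where it says the series, first, only, none or still open, it means among the compounds named here.

- compound 1 `CC(=O)Nc1ccc(S(=O)(=O)N2C/C(=C\c3ccccc3F)C(=O)/C(=C/c3ccccc3F)C2)cc1`: 7490 nM
- compound 2 `CC(=O)Nc1ccc(S(=O)(=O)N2C/C(=C\c3cccc([N+](=O)[O-])c3)C(=O)/C(=C/c3ccccc3F)C2)cc1`: 10200 nM

Both values come from a functional assay on SMMC-7721 cells (Homo sapiens) for cytotoxicity, read by MTT assay, with a stated time of 24 h; on this read-out lower numbers stand for stronger inhibition and higher numbers for weaker inhibition. Among the measured compounds shown here, compound 2 lies within the scatter of compound 1, the only other measured compound, so the two cannot be ranked.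

The next compound is compound 3 `CC(=O)Nc1ccc(S(=O)(=O)N2C/C(=C\c3ccc(C#N)cc3)C(=O)/C(=C/c3ccccc3F)C2)cc1`. Its difference from compound 2 is 4-cyanophenyl in place of 3-nitrophenyl on a double-bonded chain carbon bound to a double-bonded ring carbon. The exchange is on a double-bonded chain carbon bound to a double-bonded ring carbon, where 4-cyanophenyl takes the place of 3-nitrophenyl.

For the measured compounds named here, only one measured step bears on this change: a 1.4-fold higher number from compound 1 to compound 2 (0.13 log units; within the scatter). It is a change of group at the same kind of place, and it stays within the scatter. Going by the values given here, no measured compound carries 4-cyanophenyl, so the data offer no direct reading of that group. With this single small step as the guide, no change beyond the scatter is expected in this assay, and the estimate stays close to compound 1 at 7490 nM and compound 2 at 10200 nM.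

The expected step is a 1.1-fold lower number from compound 2 to compound 3 (0.05 log units; within the scatter).

For compound 3 the estimated value is 9000 nM, with an expected range from 4500 nM to 18000 nM.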

Compound 3, half-maximal inhibitory concentration: 3150 nM
Compound 3: the middle estimate sits 2.9-fold (0.46 log units) above what was measured, and the stated range ends above it.
By their numbers in this assay, from the lowest: compound 3; then compounds 1 and 2 (each within the scatter of the next).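

In this assay, the place on a double-bonded chain carbon bound to a double-bonded ring carbon now shows a response to the group it carries: 4-cyanophenyl in place of 3-nitrophenyl gives a 3.2-fold lower number from compound 2 to compound 3 (0.51 log units; beyond the scatter), and 4-cyanophenyl in place of 2-fluorophenyl gives a 2.4-fold lower number from compound 1 to compound 3 (0.38 log units; beyond the scatter). Among the compounds shown here, both steps are modest but beyond the scatter, whereas the only earlier exchange at this place stayed within it, so compound 3 stands apart as the lowest of the three numbers and the place is not indifferent to the group it carries. No measurement on these compounds bears on why 4-cyanophenyl reads differently from the other two groups.

The compounds shown do not tell whether the step belongs to the nitrile itself or to where it stands on the phenyl ring, as the groups compared differ in both. Also open, on these data alone, are how a phenyl ring carrying an amine or a carboxylic acid would read at this place, and whether 4-cyanophenyl would give a similar step with a group other than the 2-fluorophenyl common to all three compounds.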